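Pyrrolidin-1-yl for methylsulfanyl on two cores

A few compounds are considered here, and "the series" means these few. Any claim that something is new, unique, unknown or untested is made for them only; others in the source may bear on it.

Compound 1 `CSc1nc(Br)c(C(=O)c2ccccc2)s1` and compound 2 `O=C(c1ccccc1)c1sc(N2CCCC2)nc1Br` share one core. In a functional assay on MCF7 cells (Homo sapiens) for cytotoxicity, read by MTT assay, with a stated time of 72 h (a lower number here means a stronger inhibitor, a higher number a weaker inhibitor), compound 1 gives 67000 nM and compound 2 gives 69000 nM; the change pyrrolidin-1-yl in place of methylsulfanyl on an aromatic carbon made a step of a 1.0-fold higher number from compound 1 to compound 2 (0.01 log units; within the scatter). Compound 3 `COC(=O)c1sc2nc(SC)sc2c1C` sits on another core; the difference between the two cores is not broken down here. In this assay compound 3 gives 69000 nM, level with compound 2 at the digits printed. Compound 4 `COC(=O)c1sc2nc(N3CCCC3)sc2c1C` carries the same kind of change, (pyrrolidin-1-yl in place of methylsulfanyl on an aromatic carbon). The surroundings differ: in compound 4 the aromatic carbon is part of a fused or bridged system of two rings, whereas in compound 1 it is two ring bonds from the ring atom that bears a bromo group and two ring bonds from the ring atom that bears a group of 8 heavy atoms. Because the earlier step of a 1.0-fold higher number from compound 1 to compound 2 (0.01 log units; within the scatter) lay within the scatter, compound 4 is expected to show a step of about no change at the digits printed from compound 3 to compound 4 (within the scatter). The estimate for compound 4 is 69000 nM, with a range from 40000 nM to 120000 nM.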

Compound 4, half-maximal inhibitory concentration: 56000 nM
Estimate against measurement, compound 4: 1.2-fold (0.09 log units) above, within the range that was stated.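

In this assay the new step is a 1.2-fold lower number from compound 3 to compound 4 (0.09 log units; within the scatter), so pyrrolidin-1-yl in place of methylsulfanyl gives a step within the scatter on this core, as it does on the core of compound 1. The two steps do not differ across the cores: the same change on two cores in this assay, a 1.0-fold higher number (0.01 log units; within the scatter) from compound 1 to compound 2 and a 1.2-fold lower number (0.09 log units; within the scatter) from compound 3 to compound 4, 1.3-fold (0.10 log units) apart, within the scatter of two such steps. Among the compounds shown here, this shows agreement only for these two cores in this one assay; neither step lies beyond the scatter, so no step of real size has been seen to carry from one core to the other.

On these data alone, it remains open whether a primary amine, morpholin-4-yl or a longer alkylsulfanyl chain in place of methylsulfanyl would give a step beyond the scatter on either core. As far as these compounds go, whether the same agreement holds on other cell lines also stays open.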